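Ester Chain Length and Cytotoxicity in a Small Series

The source may report more compounds than this note shows. Statements on the series, on what has been measured and on what is new or still open speak of the compounds shown alone.

Three compounds share a core with a trifluoromethyl group and differ in the ester and in the ring substituents. Compound 1 `COC(=O)c1c(C(F)(F)F)[n+]([O-])c2ccccc2[n+]1[O-]` carries a methoxycarbonyl group; compound 3 `CCOC(=O)c1c(C(F)(F)F)[n+]([O-])c2ccccc2[n+]1[O-]` carries an ethoxycarbonyl group on the same core; compound 2 `CCOC(=O)c1c(C(F)(F)F)[n+]([O-])c2cc(C)c(C)cc2[n+]1[O-]` carries an ethoxycarbonyl group on a core bearing two methyl groups. In an ADME assay on J774 cells (Mus musculus) for cytotoxicity, read by MTT assay, with a stated time of 48 h (on this read-out lower numbers stand for stronger inhibition and higher numbers for weaker inhibition), compound 1 gives 19000 nM, compound 3 gives 4000 nM, and compound 2 gives 4000 nM.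

Between compound 3 and compound 1 the change is hydrogen in place of methyl on a saturated chain carbon bound to an oxygen next to a carbonyl group. In this assay this produced a 4.8-fold higher number from compound 3 to compound 1 (0.68 log units; beyond the scatter). The difference between the cores of compound 2 and compound 3 is not broken down here; their values are within the scatter of each other.

Compound 4 `COC(=O)c1c(C(F)(F)F)[n+]([O-])c2cc(C)c(C)cc2[n+]1[O-]` is not yet measured. Its difference from compound 2 is hydrogen in place of methyl on a saturated chain carbon bound to an oxygen next to a carbonyl group, the same change as from compound 3 to compound 1. Because compound 3 to compound 1 gave a 4.8-fold higher number from compound 3 to compound 1 (0.68 log units; beyond the scatter), compound 4 is expected to show a similar step, a 4.3-fold higher number from compound 2 to compound 4 (0.63 log units; beyond the scatter). For compound 4 the estimated value in this assay is 17000 nM, expected to lie between 7000 nM and 40000 nM.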

Compound 4, half-maximal inhibitory concentration: 4000 nM
The estimate for compound 4 lay 4.3-fold (0.63 log units) above the measured number; measured number below the stated range.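

On the core bearing two methyl groups, going from ethoxycarbonyl to methoxycarbonyl in this assay gives no change at the digits printed from compound 2 to compound 4 (within the scatter). An ester change that mattered on one core therefore did not repeat on the other, so in these two pairs its size depends on the core that carries it: the same change on two cores in this assay, a 4.8-fold higher number (0.68 log units; beyond the scatter) from compound 3 to compound 1 and no change at the digits printed (within the scatter) from compound 2 to compound 4, 4.8-fold (0.68 log units) apart, beyond the scatter of two such steps

This does not show why the two cores differ, and two pairs are too few to tell which result would be the more usual one on a further core in this series.

The compounds shown leave open how a longer chain such as a propyl ester, or a carboxylic acid in place of the ester, would behave on either core. They also leave open whether a single methyl group or a chlorine atom on the ring would give a step like the one on the core of compound 3 or the flat result seen with the two methyl groups.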